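A few compounds are considered here, and "the series" means these few. Any claim that something is new, unique, unknown or untested is made for them only; others in the source may bear on it.

In a physicochemical assay for solubility, read by HPLC, using the shake flask method, in phosphate buffer, with a stated time of 20 h, at pH 6.5 (on this read-out lower numbers stand for lower solubility and higher numbers for higher solubility), compound 1 (`CN1CCN(C2CCN(c3nccc4[nH]c(-c5cc(F)cc(F)c5)nc34)CC2)CC1`) gives 200000 nM, and compound 2 (`Fc1cc(F)cc(-c2nc3c(N4CCC(CN5CCNCC5)CC4)nccc3[nH]2)c1`) gives 190000 nM. Among the measured compounds shown here, these two values lie within the scatter of each other, so compound 2 stands level with the only other measured compound. The next compound is compound 3 (`Cn1ccnc1N1CCN(CC2CCN(c3nccc4[nH]c(-c5cc(F)cc(F)c5)nc34)CC2)CC1`), with 1-methyl-1H-imidazol-2-yl in place of hydrogen on an amine nitrogen in a ring. For the measured compounds named here, only one measured step is available, a 1.1-fold lower number from compound 1 to compound 2 (0.02 log units; within the scatter), which places (piperazin-1-yl)methyl where 4-methylpiperazin-1-yl stood on a saturated ring carbon. Going by the values given here, that step stays within the scatter, but it bears only loosely on the new change, since no measured compound carries the entering group. The data therefore set neither the direction nor the size of the next step in this assay. A moderate move to a lower number is expected, though a result within the scatter of compound 2 would not be surprising. Among the compounds with values here, the expected change is a 2.4-fold lower number from compound 2 to compound 3 (0.38 log units; beyond the scatter), and this estimate has no measured precedent. For compound 3 the estimated value is 80000 nM, with an expected range from 20000 nM to 200000 nM.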

Compound 3, solubility: 135000 nM
Estimate against measurement, compound 3: 1.7-fold (0.23 log units) below; the measured number falls inside the stated range.
By their numbers in this assay, from the lowest: compounds 3, 2 and 1 (each within the scatter of the next).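

In this assay, placing 1-methyl-1H-imidazol-2-yl on the amine nitrogen in the ring, in place of hydrogen, gives a 1.4-fold lower number from compound 2 to compound 3 (0.15 log units; within the scatter). Among the compounds shown here, this is the first measured change at this nitrogen; the earlier step, a 1.1-fold lower number from compound 1 to compound 2 (0.02 log units; within the scatter), concerned a different exchange on a saturated ring carbon. The new step shows that a group of 6 heavy atoms, with one five-membered aromatic ring, can enter here without a step beyond the scatter, although this rests on a single pair of compounds, and no measured evidence bears on why the read-out stays within the scatter.

For the compounds shown here, with only one entering group at this nitrogen, it remains open whether an acetyl group, a phenyl ring or a short chain ending in a carboxylic acid would also stay within the scatter of compound 2. Also open, going by these compounds, is whether the methyl group on the entering ring matters, which the unsubstituted 1H-imidazol-2-yl group at the same nitrogen would address.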